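The compounds below may be only part of what the source reports. "The series", "measured", "known", "first", "only" and "open" are said of these compounds alone.

In an assay on isolated protein for activation of cGMP-dependent protein kinase 1 (Homo sapiens), read by ADP-Glo, with stated times of 120 min and 40 min (on this read-out lower numbers stand for an effect already at smaller amounts and higher numbers for an effect only at larger amounts of compound), the measured compounds are:
compound 1 `OC[C@@H](O[C@H]1CCCN(Cc2ncc[nH]2)[C@H]1c1ccccc1)c1cc(Cl)cc(Cl)c1`, giving 7000 nM;
compound 2 `Clc1cc(Cl)cc(CO[C@H]2CCCN(Cc3ccncc3)[C@H]2c2ccccc2)c1`, which reaches only the limit of > 200000 nM;
compound 3 `COC(=O)Nn1c(C[C@H]2CCC[C@H](OCc3cc(C(F)(F)F)cc(C(F)(F)F)c3)[C@@H]2c2ccccc2)n[nH]c1=O`, giving 4500 nM.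

Compound 2 thus sits at the limit of > 200000 nM in this assay, at which 1 of the 3 values shown sits; its value is a limit of the measurement, not a number, and compound 2 is the only one of the three that ends there. The unmeasured compound 4 `CN1CCC[C@H](OCc2cc(Cl)cc(Cl)c2)[C@@H]1c1ccccc1` differs from compound 2 by hydrogen in place of pyridin-4-yl on a saturated chain carbon bound to an amine nitrogen in a ring. Going by the values given here, no pair among the measured compounds differs in one place only, so no measured step shows how much such a change moves the read-out. The expectation is that the step of an at least 1.3-fold lower number from compound 2 to compound 4 (0.12 log units; that floor lies within the scatter) stays small, with compound 4 probably again near or at the limit. Compound 4 is therefore estimated at 150000 nM, in a range from 30000 nM to 400000 nM.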

Compound 4, half-maximal effective concentration: > 200000 nM
Compound 4: a limit, no number; the forecaster's own chance of this, stated with the estimate: 60%; at least 1.3-fold (0.12 log units) between middle value and limit.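

Compound 2 and compound 4 both end at a limit rather than a number, so no step between them can be read: the limit of > 200000 nM in this assay, at which 2 of the 4 values shown sit.

The compounds shown leave open how far hydrogen in place of pyridin-4-yl moves the read-out.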